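A Rearranged Dimethylphenyl Group on the Sulfonamide Nitrogen

This account rests on a few compounds, and the source may have more. Where it says the series, first, only, none or still open, it means among the compounds named here.

Compound 1 `Cc1cccc(NS(=O)(=O)c2ccc(N3CCNC3=O)cc2)c1` gives 200 nM
Compound 2 `CCc1cccc(NS(=O)(=O)c2ccc(N3CCNC3=O)cc2)c1` gives 230 nM
Compound 3 `Cc1cc(C)cc(NS(=O)(=O)c2ccc(N3CCNC3=O)cc2)c1` gives 190 nM

All three compounds were tested in a functional assay on SK-OV-3 cells (Homo sapiens) for antiproliferative activity, read by sulforhodamine B assay, with a stated time of 48 h (a lower number here means a stronger inhibitor, a higher number a weaker inhibitor), and their numbers sit close together. Compound 3 gives 190 nM and stands level with the other two: the data show a 1.1-fold lower number from compound 1 to compound 3 (0.02 log units; within the scatter) and also a 1.2-fold lower number from compound 2 to compound 3 (0.08 log units; within the scatter) on the way to it. The remaining step is just as small, with a 1.2-fold higher number from compound 1 to compound 2 (0.06 log units; within the scatter) in this series.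

Compound 4 `Cc1ccc(C)c(NS(=O)(=O)c2ccc(N3CCNC3=O)cc2)c1` keeps the shared core and carries 2,5-dimethylphenyl in place of 3,5-dimethylphenyl on a sulfonamide nitrogen. Going by the values given here, no measured step makes this exact exchange. The nearest is a 1.2-fold lower number from compound 2 to compound 3 (0.08 log units; within the scatter) for another swap of one group on that nitrogen for another. All three measured steps are small, so no step beyond the scatter is expected in this assay. Yet no measured compound carries the 2,5-dimethylphenyl group, so the expected range stays wide. The expected change is a 1.2-fold higher number from compound 3 to compound 4 (0.06 log units; within the scatter) in this estimate. For compound 4 the estimate is 220 nM (expected range 90 nM to 550 nM).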

Compound 4, half-maximal inhibitory concentration: 72 nM
For compound 4 the middle estimate is 3.1-fold (0.49 log units) above the measured one; measured number below the stated range.
By their numbers in this assay, from the lowest: compound 4; then compounds 3, 1 and 2 (each within the scatter of the next).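

Rearranging the two methyl groups, with the same atoms on the same kind of ring, is enough to move the result: 2,5-dimethylphenyl in place of 3,5-dimethylphenyl on the sulfonamide nitrogen gives a 2.6-fold lower number from compound 3 to compound 4 (0.42 log units; beyond the scatter) in this assay and is the first step in the series to pass beyond the scatter. The earlier compounds shown here suggested that this group tolerated small changes without any real effect, but compound 4 also stands apart from the other two, with a 3.2-fold lower number from compound 2 to compound 4 (0.50 log units; beyond the scatter) and a 2.8-fold lower number from compound 1 to compound 4 (0.44 log units; beyond the scatter) making it the strongest of the four. That last step adds one methyl to compound 1, as the step to compound 3 also does, so among these compounds the result depends on where the added methyl lies and not merely on its presence.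

As far as these compounds go, whether a chlorine atom or a methoxy group could replace either methyl of the 2,5-dimethylphenyl group and keep this lower number remains open. The data available here offer no explanation for the step.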